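The source may report more compounds than this note shows. Statements on the series, on what has been measured and on what is new or still open speak of the compounds shown alone.

In a functional assay on PC-3 cells (Homo sapiens) for cytotoxicity, read by MTT assay, with a stated time of 24 h (on this read-out lower numbers stand for stronger inhibition and higher numbers for weaker inhibition), compound 3 `Cc1ccc(/C=C2\CN(Cc3cn(Cc4ccccc4F)nn3)C/C(=C\c3ccc(C)cc3)C2=O)cc1` gives 8800 nM. Compound 2 `O=C1/C(=C/c2ccccc2F)CN(C(=S)SCc2cn(Cc3ccccc3F)nn2)C/C1=C\c1ccccc1F` reaches only the limit of the assay, > 80000 nM. Compound 1 `O=C1/C(=C/c2ccccc2F)CN(C(=S)SCc2cn(Cc3ccccc3Cl)nn2)C/C1=C\c1ccccc1F` likewise reaches only the limit, > 80000 nM. The two share a core that differs from the core of compound 3, and that difference between the two cores is not broken down here. Between them one change is made, (chloro in place of fluoro on an aromatic carbon), and its effect is a step that the two limits leave unreadable from compound 2 to compound 1, because the limit of > 80000 nM in this assay, at which 2 of the 3 values shown sit, leaves no number to compare on either side.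

Compound 4 `Cc1ccc(/C=C2\CN(Cc3cn(Cc4ccccc4Cl)nn3)C/C(=C\c3ccc(C)cc3)C2=O)cc1` has not yet been measured. It carries the same change relative to compound 3, (chloro in place of fluoro on an aromatic carbon), made on the same kind of place. Since the earlier step from compound 2 to compound 1 gives no readable size to lean on, the expectation for compound 4 rests on compound 3 alone, with its value 8800 nM. The step from compound 3 to compound 4 is expected to be a 1.1-fold lower number from compound 3 to compound 4 (0.04 log units; within the scatter), within the usual scatter. Compound 4 is therefore estimated at 8000 nM, between 3000 nM and 25000 nM.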

Compound 4, half-maximal inhibitory concentration: 8900 nM
For compound 4 the middle estimate is 1.1-fold (0.05 log units) below the measured one, and the stated range covers the measured number.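

On the core of compound 3, the change from 2-fluorobenzyl to 2-chlorobenzyl gives a 1.0-fold higher number from compound 3 to compound 4 (0.00 log units; within the scatter) in this assay, so on this core the two halogens cannot be told apart on this read-out. The same change on the core shared by compound 2 and compound 1 cannot be read, because neither compound gives a number to compare, only a limit: the limit of > 80000 nM in this assay, at which 2 of the 4 values shown sit. The result therefore rests on a single readable pair; it shows that the change leaves the number in place on the core of compound 3, but not that the same would hold on any other core.

The compounds shown leave open whether a different group in place of the fluoro or chloro, such as an amine, a methoxy group or a carboxylic acid, would move the number on the core of compound 3. They also leave open how each of the differences between the two cores bears on this read-out.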